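The compounds below may be only part of what the source reports. "The series", "measured", "known", "first", "only" and "open" are said of these compounds alone.

Compound 1 `c1ccc2c(c1)CN[C@@H](CN(CCCCNCC1CCNCC1)[C@H]1CCCc3cccnc31)C2` gives > 30000 nM in a functional assay on cells for agonist activity at C-X-C chemokine receptor type 4 (Homo sapiens), read by fluorescence and calcium flux, with a stated time of 90 s (on this read-out higher numbers stand for an effect only at larger amounts of compound and lower numbers for an effect already at smaller amounts), which is a limit of the assay rather than a number.
Compound 2 `c1ccc2c(c1)CN[C@@H](CN(CCCCNC1CCCCC1)[C@H]1CCCc3cccnc31)C2` gives > 30000 nM in this assay, again only a limit.

Going by the values given here, compound 2 therefore stands at the edge of what this assay can report: no effect was seen up to the highest amount tested, and the same holds for the only other compound measured, as both values sit at the limit of > 30000 nM in this assay, at which 2 of the 2 values shown sit. Among the compounds with values here, the one step between measured compounds, a step that the two limits leave unreadable from compound 1 to compound 2, cannot be read in size or direction, since both ends are limits.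

Compound 3 `NCc1ccccc1CN(C[C@H]1Cc2ccccc2CN1)[C@H]1CCCc2cccnc21` differs from compound 2 in one place: 2-(aminomethyl)phenyl in place of 3-(cyclohexylamino)propyl on a saturated chain carbon bound to an amine nitrogen. Within the data shown here, no measured step gives a readable size for a change of this kind, so the expectation rests on the two limits alone. With both measured compounds showing no agonist effect within the tested range, compound 3 is expected to behave the same way, and the step of a number no higher from compound 2 to compound 3 (the limit leaves the size open) is expected to be none that can be read. The estimate for compound 3 is 30000 nM, within 10000 nM to 100000 nM, most likely reported again only as a limit.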

Compound 3, half-maximal effective concentration: > 30000 nM
Compound 3: no number, only a limit (the forecaster's own chance of this, stated with the estimate: 85%); the middle value sits exactly at the limit.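

In this assay compound 3 gives > 30000 nM, again a limit and not a number. The steps from compound 1 and from compound 2 to compound 3 therefore cannot be read, in size or in direction, and every value shown sits at the same edge: the limit of > 30000 nM in this assay, at which 3 of the 3 values shown sit.

From the compounds shown here alone, what stays open is whether any change to these compounds would bring a measurable effect within the tested range.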